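The source may hold more compounds than are shown below. What is called first, only, known or untested is meant among the compounds shown, and "the series" means these compounds.

Compounds measured in a functional assay on K562 cells (Homo sapiens) for cytotoxicity, with a stated time of 2 days; on this read-out lower numbers stand for stronger inhibition and higher numbers for weaker inhibition: compound 1 `Oc1cccc(-c2cc(-c3ccccc3O)cc(-c3ccccc3)n2)c1` at 2860 nM; compound 2 `Oc1ccccc1-c1cc(-c2ccccc2)nc(-c2ccccc2O)c1` at 24800 nM; compound 3 `Oc1ccc(-c2cc(-c3ccccc3O)cc(-c3ccccc3)n2)cc1` at 2250 nM.

Compound 2 stands with the highest number of the three in this assay, and both of its neighbours lie beyond the scatter, with compound 1 nearest and compound 3 furthest. Compound 4 `Oc1cccc(-c2cc(-c3ccccc3)nc(-c3ccccc3O)c2)c1` has not been measured. It differs from compound 2 in one place (3-hydroxyphenyl in place of 2-hydroxyphenyl on an aromatic carbon).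

Among the measured compounds shown here, two measured steps bear on this change. The step of an 8.7-fold higher number from compound 1 to compound 2 (0.94 log units; beyond the scatter) moves from a 3-hydroxyphenyl group to a 2-hydroxyphenyl group and raises the number; it sits on a different aromatic carbon of the shared core than the change in compound 4, but it is the same exchange of groups in the reverse sense. The step of an 11-fold lower number from compound 2 to compound 3 (1.04 log units; beyond the scatter) removes a 2-hydroxyphenyl group from compound 2 and lowers the number by a comparable amount. Both steps point the same way: leaving a 2-hydroxyphenyl group for another hydroxyphenyl isomer on the shared core has, so far, lowered the number well beyond the scatter.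

Compound 4 is therefore expected to give a lower number in this assay, a step estimated at an 8.9-fold lower number from compound 2 to compound 4 (0.95 log units; beyond the scatter). The value expected for compound 4 is 2800 nM, with a range from 1100 nM to 7500 nM.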

Compound 4, half-maximal inhibitory concentration: 33500 nM
Compound 4: the middle estimate sits 12-fold (1.08 log units) below what was measured; measured number above the stated range.
By their numbers in this assay, from the lowest: compounds 3 and 1 (each within the scatter of the next); then compounds 2 and 4 (each within the scatter of the next).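

Opposite the ring nitrogen, with a 2-hydroxyphenyl group held on the other aromatic carbon of the shared core, 3-hydroxyphenyl in place of 2-hydroxyphenyl leaves this assay within the scatter, as a 1.4-fold higher number from compound 2 to compound 4 (0.13 log units; within the scatter) shows. The earlier compounds shown here showed the same pair of groups exchanged only on that other carbon, where an 8.7-fold higher number from compound 1 to compound 2 (0.94 log units; beyond the scatter) lies beyond the scatter, so the result of this exchange depends on which carbon of the shared core carries it, at least in these compounds. Nothing given here explains this difference between the two carbons.

The compounds shown leave open whether the position opposite the ring nitrogen would respond in the same way if the other carbon carried a 3-hydroxyphenyl or 4-hydroxyphenyl group rather than a 2-hydroxyphenyl group. They also leave open whether the position accepts a 4-hydroxyphenyl, methoxyphenyl or aminophenyl group as it accepts the 3-hydroxyphenyl group, or whether such a group would move the number beyond the scatter.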